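Alkoxy chain to dialkylamino chain: the dibutyl member

The source may report more compounds than this note shows. Statements on the series, on what has been measured and on what is new or still open speak of the compounds shown alone.

Working notes on a series sharing one core, varied only in the chain on the ring oxygen. Compound 1 `CCCCCCOc1c(-c2cc(OC)c(OC)c(OC)c2)oc2ccccc2c1=O` carries a plain hexyl chain and in a functional assay on LNCaP cells (Homo sapiens) for antiproliferative activity, read by WST assay, with a stated time of 3 days (on this read-out lower numbers stand for stronger inhibition and higher numbers for weaker inhibition), compound 1 gives 19600 nM. Compound 2 `CCN(CC)CCCCOc1c(-c2cc(OC)c(OC)c(OC)c2)oc2ccccc2c1=O` in this assay gives 13500 nM, and compound 3 `CCCN(CCC)CCCOc1c(-c2cc(OC)c(OC)c(OC)c2)oc2ccccc2c1=O` in this assay gives 17900 nM. Compound 1 stands as the highest of the three numbers, yet each step from it lies within the scatter: a 1.5-fold lower number from compound 1 to compound 2 (0.16 log units; within the scatter) and a 1.1-fold lower number from compound 1 to compound 3 (0.04 log units; within the scatter). The step of a 1.3-fold higher number from compound 2 to compound 3 (0.12 log units; within the scatter) is likewise within the scatter, so the three chains, with or without a nitrogen, are not told apart here.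

The unmeasured compound 4 `CCCCN(CCCC)CCCOc1c(-c2cc(OC)c(OC)c(OC)c2)oc2ccccc2c1=O` differs from compound 1 as follows: dibutylamino in place of propyl on a saturated chain carbon, three bonds along the chain from an oxygen on an aromatic ring. Within the data shown here, the nearest precedent is the step from compound 1 to compound 3, which swaps a propyl for a dipropylamino at the same place and gives a 1.1-fold lower number from compound 1 to compound 3 (0.04 log units; within the scatter); the step to compound 2, with a diethylamino one bond further out, gives a 1.5-fold lower number from compound 1 to compound 2 (0.16 log units; within the scatter). Both are within the scatter, so no step beyond the scatter is expected in this assay for the dibutylamino either. Compound 4 is therefore estimated at 16000 nM, with a range from 7000 nM to 36000 nM. The expected step is a 1.2-fold lower number from compound 1 to compound 4 (0.09 log units; within the scatter).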

Compound 4, half-maximal inhibitory concentration: 9000 nM
For compound 4 the middle estimate is 1.8-fold (0.25 log units) above the measured one; low and high end bracket the measured number.
By their numbers in this assay, from the lowest: compounds 4, 2, 3 and 1 (each within the scatter of the next, the first and the last beyond it).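

In this assay the dibutylamino chain is the only one of the series shown to separate from the plain alkyl chain of compound 1: the change gives a 2.2-fold lower number from compound 1 to compound 4 (0.34 log units; beyond the scatter) and so turns a position that had looked flat into one with a modest response. That separation does not extend to the other amines, since the change from dipropylamino gives a 2.0-fold lower number from compound 3 to compound 4 (0.30 log units; within the scatter) and the comparison with the diethylamino chain gives a 1.5-fold lower number from compound 2 to compound 4 (0.18 log units; within the scatter), which leaves compound 4 not told apart from compound 2 or compound 3. Nothing at hand bears on the reason for the step from compound 1, so it stands as an observation without a cause.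

With a single step beyond the scatter, the compounds shown leave open whether the number depends in any regular way on the length of the alkyl groups on the nitrogen, and a dipentylamino group at the same place would test that. Also open, from the compounds shown here alone, is how a ring amine such as piperidinyl, or a chain ending in a carboxylic acid, would compare with the dibutylamino chain at this position.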